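The compounds below may be only part of what the source reports. "The series", "measured", "known", "first", "only" and "open" are said of these compounds alone.

Working notes on the series. Compound 1 `Cc1ccccc1-c1nnc(N(C)N)s1` gives 41 mg/kg in a functional assay on the whole organism with Mus musculus as the target, with a stated time of 1 h; on this read-out higher numbers stand for an effect only at larger amounts of compound and lower numbers for an effect already at smaller amounts. Among the measured compounds shown here, compound 2 `Cc1ccccc1-c1nnc(NNC(C)C)s1` gives 54 mg/kg in this assay, the higher of the two numbers, though the single measured step, a 1.3-fold higher number from compound 1 to compound 2 (0.12 log units; within the scatter), stays within the scatter. Compound 3 `Cc1ccccc1-c1nnc(N(C)NC(C)C)s1` carries methyl in place of hydrogen on a nitrogen on an aromatic ring, a nitrogen whose other neighbours are an amine nitrogen and an aromatic carbon. For the measured compounds named here, no measured step isolates this change; the only step available, a 1.3-fold higher number from compound 1 to compound 2 (0.12 log units; within the scatter), concerns another exchange on the same nitrogen and stayed within the scatter, so no shift beyond the scatter is expected in this assay. The expected step is a 1.1-fold lower number from compound 2 to compound 3 (0.03 log units; within the scatter). Compound 3 is therefore estimated at 50 mg/kg, within 25 mg/kg to 100 mg/kg.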

Compound 3, dose for half-maximal effect: 38 mg/kg
Compound 3: middle estimate off by 1.3-fold (0.12 log units), on the high side, within the range that was stated.
By their numbers in this assay, from the lowest: compounds 3, 1 and 2 (each within the scatter of the next).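

Methyl in place of hydrogen on the nitrogen on the aromatic ring can now be read directly: a 1.4-fold lower number from compound 2 to compound 3 (0.15 log units; within the scatter) in this assay. Isopropyl in place of hydrogen on the amine nitrogen gives a 1.1-fold lower number from compound 1 to compound 3 (0.03 log units; within the scatter), so compounds 1, 2 and 3 all stay within the scatter of one another, whether these nitrogens carry methyl, isopropyl or both. No measurement is at hand that would account for this result.

Open, as far as these compounds go, is whether a longer chain such as butyl, or an acetyl group, on either nitrogen moves the number beyond the scatter. Also open, from the compounds shown here alone, is whether a carboxylic acid on the chain does so.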